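Compound 4: 1,3-benzothiazol-2-yl in place of 1H-benzimidazol-2-yl

The source may report more compounds than this note shows. Statements on the series, on what has been measured and on what is new or still open speak of the compounds shown alone.

In a functional assay on Bel-7402 cells (Homo sapiens) for cytotoxicity, read by MTT assay, with a stated time of 48 h (a lower number here means a stronger inhibitor, a higher number a weaker inhibitor), compound 1 `CCn1cc(-c2nc3ccccc3[nH]2)c(=O)c2cc(F)c(N3CCNC(C)C3)c(F)c21` gives 30200 nM. Compound 2 `CCn1cc(-c2nc3ccccc3o2)c(=O)c2cc(F)c(N3CCNCC3)nc21` gives 16800 nM, and these two values lie within the scatter of each other. Compound 3 `CCn1cc(-c2nc3ccccc3s2)c(=O)c2cc(F)c(N3CCNCC3)nc21` gives 2400 nM, the lowest number of the three and beyond the scatter from both others.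

Compound 4 `CCn1cc(-c2nc3ccccc3s2)c(=O)c2cc(F)c(N3CCNC(C)C3)c(F)c21` keeps the core of compound 1 and changes one group: 1,3-benzothiazol-2-yl in place of 1H-benzimidazol-2-yl on an aromatic carbon. 1,3-benzothiazol-2-yl takes the place of 1H-benzimidazol-2-yl on an aromatic carbon.

Within the data shown here, one measured step bears on this change: a 7.0-fold lower number from compound 2 to compound 3 (0.85 log units; beyond the scatter). It is modest but beyond the scatter, and it brings in the same 1,3-benzothiazol-2-yl, in place of 1,3-benzoxazol-2-yl. The evidence is indirect, since that step has a different leaving group and sits on a core other than that of compound 1. Among the measured compounds shown here, no measured pair starts from 1H-benzimidazol-2-yl.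

A step toward a lower number is expected in this assay, similar to or somewhat smaller than the measured one, and the expected step is a 5.0-fold lower number from compound 1 to compound 4 (0.70 log units; beyond the scatter). For compound 4 the estimated value is 6000 nM, with an expected range of 1800 nM to 18000 nM.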

Compound 4, half-maximal inhibitory concentration: 15000 nM
For compound 4 the middle estimate is 2.5-fold (0.40 log units) below the measured one, and the stated range covers the measured number.
By their numbers in this assay, from the lowest: compound 3; then compounds 4, 2 and 1 (each within the scatter of the next).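

On the core of compound 1, 1,3-benzothiazol-2-yl and 1H-benzimidazol-2-yl cannot be told apart on this aromatic carbon in this assay, with a 2.0-fold lower number from compound 1 to compound 4 (0.30 log units; within the scatter). The exchange keeps the count of 9 heavy atoms and goes from 1 hydrogen-bond donor to 0 hydrogen-bond donors, and this leaves the reading within the scatter, so the position tolerates this swap on this core. Among these compounds, the earlier step, a 7.0-fold lower number from compound 2 to compound 3 (0.85 log units; beyond the scatter), brought in the same 1,3-benzothiazol-2-yl from 1,3-benzoxazol-2-yl on a different core, so a step beyond the scatter for this group is seen only in that setting, and no information at hand explains why the two groups read alike here.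

The compounds shown leave open how 1,3-benzoxazol-2-yl would read on the core of compound 1, which would allow the two steps to be compared on one core. They also leave open whether a carboxylic acid or an amide on this aromatic carbon would move the number beyond the scatter from compound 1 in this assay, where the fused aromatic groups so far stay within it.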